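Replacing the Carbamate on the Ring Nitrogen with a Cyclobutylmethyl Group

A few compounds are considered here, and "the series" means these few. Any claim that something is new, unique, unknown or untested is made for them only; others in the source may bear on it.

Measured compounds:
compound 1 `CC(C)(C)OC(=O)N1CCC(O[C@H]2CC[C@@H](Oc3ccc(S(C)(=O)=O)cc3)CC2)CC1` gives 120%
compound 2 `CC(C)OC(=O)N1CCC(O[C@H]2CC[C@H](Oc3ccc(S(C)(=O)=O)nc3)CC2)CC1` gives 101%
compound 3 `CC(C)OC(=O)N1CCC(O[C@H]2CC[C@H](Oc3cnc(S(C)(=O)=O)cn3)CC2)CC1` gives 110%

All three compounds share a core and were tested in a functional assay on isolated protein for agonist activity at Glucose-dependent insulinotropic receptor (Homo sapiens), read by HTRF and cAMP accumulation; on this read-out lower numbers stand for smaller maximal responses and higher numbers for larger maximal responses. Compound 3 stands second highest of the three numbers; its nearest neighbour is compound 2, lying within the scatter, and the furthest is compound 1, also within the scatter. Going by the values given here, the only measured step between single-change neighbours, a number 9 percentage points higher from compound 2 to compound 3 (within the scatter), swaps one aromatic ring for another on an oxygen on a saturated carbon and stays within the scatter.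

Compound 4 `CS(=O)(=O)c1cnc(O[C@H]2CC[C@H](OC3CCN(CC4(C(F)(F)F)CCC4)CC3)CC2)cn1` changes a different part of the molecule: (1-(trifluoromethyl)cyclobutyl)methyl in place of isopropoxycarbonyl on an amine nitrogen in a ring. Among the compounds with values here, no measured step touches this amine nitrogen in a ring, so the data give no direct guide. Within the data shown here, the one step that exists, a number 9 percentage points higher from compound 2 to compound 3 (within the scatter), is small, and all three measured values sit within the scatter of each other, so the expected step of a number 2 percentage points lower from compound 3 to compound 4 (within the scatter) is none beyond the scatter. Compound 4 is therefore estimated to reach 108%, with a range from 88% to 125%.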

Compound 4, largest response reached (Emax), in percent of the reference or control that the assay uses: 96%
Compound 4: middle estimate off by 12 percentage points, on the high side; low and high end bracket the measured number.
By their numbers in this assay, from the lowest: compounds 4, 2, 3 and 1 (each within the scatter of the next, the first and the last beyond it).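

In this assay, the amine nitrogen in the ring proves to be a position where a change can move the maximal response: a number 14 percentage points lower from compound 3 to compound 4 (beyond the scatter), a modest step, but the only one shown that lies beyond the scatter. The swap takes away isopropoxycarbonyl, with its double bond and hydrogen-bond acceptors, and puts in (1-(trifluoromethyl)cyclobutyl)methyl, which has neither, yet compound 4 still gives 96%, so a carbamate on this nitrogen is not needed for a clear response. Nothing available explains why the response falls.

Still open, going by these compounds, is which part of the swap counts, the loss of the carbamate or the arrival of the fluorinated ring; a plain cyclobutylmethyl group or a urea on this nitrogen would help separate the two. Also open, on these data alone, is whether the same swap would give a similar step with the 6-(methylsulfonyl)pyridin-3-yl group of compound 2.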